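Benzoyl in place of (thiophen-2-yl)carbonyl on the shared core

This account rests on a few compounds, and the source may have more. Where it says the series, first, only, none or still open, it means among the compounds named here.

Compound 3 `O=C(/C=C/c1cccc([N+](=O)[O-])c1)c1ccc(NC(=O)c2cccs2)cc1` is the reference point. In a toxicity assay on FHC cells (Homo sapiens) for cytotoxicity, read by resazurin assay, with a stated time of 48 h (a lower number here means that less compound is tolerated, a higher number that more compound is tolerated), compound 3 gives 73000 nM. Compound 1 `O=C(/C=C/c1ccccc1)c1ccc(NC(=O)c2ccccc2)cc1` gives 73000 nM in this assay, level with compound 3 at the digits shown. Compound 2 `O=C(/C=C/c1cccc([N+](=O)[O-])c1)c1ccc(NC(=O)c2ccco2)cc1` returns only a limit of the assay in this assay, > 100000 nM. Among the compounds with values here, the one measured step at this position, an at least 1.3-fold lower number from compound 2 to compound 3 (0.13 log units; that floor lies within the scatter), is thiophen-2-yl in place of furan-2-yl on a carbonyl carbon; its floor lies within the scatter and its start is the limit (the limit of > 100000 nM in this assay, at which 1 of the 3 values shown sits), so it fixes no firm size.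

Compound 4 `O=C(/C=C/c1cccc([N+](=O)[O-])c1)c1ccc(NC(=O)c2ccccc2)cc1` differs from compound 3 by phenyl in place of thiophen-2-yl on a carbonyl carbon. Within the data shown here, no measured pair shows phenyl against thiophen-2-yl on a carbonyl carbon directly; compound 1 carries benzamido and sits at the same number as compound 3, though the two differ elsewhere as well. Beyond the step from furan-2-yl to thiophen-2-yl there is nothing that bears on this change. Hence no step beyond the scatter is expected in this assay in either direction, and the expected step of no change at the digits printed from compound 3 to compound 4 (within the scatter) is close to none. Compound 4 is estimated at 73000 nM, within 35000 nM to 150000 nM, with some chance that only a limit is returned.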

Compound 4, half-maximal cytotoxic concentration: > 100000 nM
Compound 4: no number, only a limit; the forecaster's own chance of this, stated with the estimate: 30%; at least 1.3-fold (0.13 log units) between middle value and limit.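

In this assay compound 4 returns only a limit of the assay, > 100000 nM. Phenyl in place of thiophen-2-yl on a carbonyl carbon now has a measured step, an at least 1.3-fold higher number from compound 3 to compound 4 (0.13 log units; that floor lies within the scatter), and the nitro group now stands alone in a pair, with nitro in place of hydrogen on an aromatic carbon giving an at least 1.3-fold higher number from compound 1 to compound 4 (0.13 log units; that floor lies within the scatter); both steps end at the limit of compound 4, so neither has a firm size. The step from compound 2 to compound 4 cannot be read, since both of its ends are limits, and the measured numbers in the series are now matched in count by limits: the limit of > 100000 nM in this assay, at which 2 of the 4 values shown sit.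

Still open, on these data alone, is how large the change from thiophen-2-yl to phenyl really is, and whether it, or the nitro change, is more than scatter at all. Also open, as far as these compounds go, is how a non-aromatic group such as cyclohexyl, or a longer alkyl chain, would read in place of phenyl on a carbonyl carbon, and whether an amine or a carboxylic acid on that phenyl would bring the number back within the readable range.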